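Triazole N-substituent survey in a biaryl diol ether series

The compounds below may be only part of what the source reports. "The series", "measured", "known", "first", "only" and "open" are said of these compounds alone.

Measured so far:
- compound 1, `O=C1COc2ccc(-n3cc(C[C@H](O)COCCOC[C@@H](O)Cc4ccc(-c5ccccc5)cc4)nn3)cc2N1`: 42500 nM
- compound 2, `O[C@H](COCCOC[C@@H](O)Cc1cn(Cc2ccc(C(F)(F)F)cc2)nn1)Cc1ccc(-c2ccccc2)cc1`: 2500 nM

Compound 1 carries the shared core with a benzoxazinone on the triazole nitrogen. In a functional assay on HCT-116 cells (Homo sapiens) for inhibition, read by MTT assay, with a stated time of 72 h (a higher number here means a weaker inhibitor of growth, a lower number a stronger inhibitor of growth), compound 1 gives 42500 nM, the highest of the two numbers; compound 2 gives 2500 nM. For the measured compounds named here, the one measured step, a 17-fold lower number from compound 1 to compound 2 (1.23 log units; beyond the scatter), shows that exchanging the group on the aromatic nitrogen moves the number strongly.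

Compound 3, `O[C@H](COCCOC[C@@H](O)Cc1cn(-c2cncc3ccccc23)nn1)Cc1ccc(-c2ccccc2)cc1`, is the next variation at the same place: a group of 10 heavy atoms (9 carbon, 1 nitrogen; one six-membered aromatic ring of carbon only, one six-membered aromatic ring with 1 hetero atom) in place of a group of 11 heavy atoms (8 carbon, 1 nitrogen, 2 oxygen; one six-membered non-aromatic ring with 2 hetero atoms, one six-membered aromatic ring of carbon only), on an aromatic nitrogen. The incoming isoquinolin-4-yl is, like the group that leaves, an aromatic system joined directly to the ring nitrogen, whereas compound 2 bears a benzyl-type group, so the measured step is only a partial guide. A lower number than compound 1 is expected, but by a smaller margin than a 17-fold lower number from compound 1 to compound 2 (1.23 log units; beyond the scatter); the expected step is a 3.5-fold lower number from compound 1 to compound 3 (0.55 log units; beyond the scatter). Compound 3 is therefore estimated at 12000 nM, within 3500 nM to 40000 nM.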

Compound 3, concentration for 50% growth inhibition: 17800 nM
Beside the measured number, compound 3's estimate is 1.5-fold (0.17 log units) below it; the range from low to high includes it.
By their numbers in this assay, from the lowest: compound 2; then compound 3; then compound 1.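

In this assay, two aromatic groups joined directly to the triazole nitrogen now give different numbers, with a 2.4-fold lower number from compound 1 to compound 3 (0.38 log units; beyond the scatter), so the number at this position also varies among directly joined groups and not only between compound 1 and the benzyl-type compound 2. Isoquinolin-4-yl in place of 4-(trifluoromethyl)benzyl gives a 7.1-fold higher number from compound 2 to compound 3 (0.85 log units; beyond the scatter), which leaves compound 2 with the lowest number of the three. No measurement at hand accounts for either difference.

Compound 2 differs from compound 3 in both its one-carbon link and its trifluoromethyl-bearing ring, and these two changes cannot yet be told apart. Unsubstituted benzyl on the same nitrogen would separate them, while a dimethylaminoethyl chain would test a group outside the aromatic types shown.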